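Methyl for hydrogen on the anilino ring of compound 2

A few compounds are considered here, and "the series" means these few. Any claim that something is new, unique, unknown or untested is made for them only; others in the source may bear on it.

Three compounds share a bicyclic diamine attached to an aromatic ring that carries an arylamino group. In an assay on cell membranes for displacement of a labelled ligand from Neuronal acetylcholine receptor; alpha4/beta2 (Rattus norvegicus) (on this read-out lower numbers stand for stronger inhibition and higher numbers for weaker inhibition), compound 1 `Clc1ccc(Nc2ccc(N3CC4CC(C3)N4)nn2)cc1Cl` gives 516 nM, compound 2 `c1ccc(Nc2ccc(N3CC4CC(C3)N4)cn2)cc1` gives 2.66 nM, and compound 3 `Fc1ccc(Nc2cncc(N3CC4CC(C3)N4)c2)cc1` gives 0.091 nM. Compound 2 thus holds the second highest number of the three; its nearest neighbour is compound 3, whose lower number lies beyond the scatter, and compound 1 stands furthest away with a higher number, also beyond the scatter. Compound 4 `Cc1ccc(Nc2ccc(N3CC4CC(C3)N4)cn2)cc1` differs from compound 2 by methyl in place of hydrogen on an aromatic carbon. Within the data shown here, no measured pair shows this step, so only a small effect, if any, is expected. For compound 4 the estimated value in this assay is 2.5 nM, in the range 0.6 nM to 10 nM. This estimate implies an expected step from compound 2 to compound 4 of a 1.1-fold lower number from compound 2 to compound 4 (0.03 log units; within the scatter), which is within the scatter.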

Compound 4, inhibition constant: 52.1 nM
For compound 4 the middle estimate is 21-fold (1.32 log units) below the measured one, and the stated range ends below it.
By their numbers in this assay, from the lowest: compound 3; then compound 2; then compound 4; then compound 1.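

In this assay, the change from phenyl to 4-methylphenyl brings a 20-fold higher number from compound 2 to compound 4 (1.29 log units; beyond the scatter) and so shows that a single added carbon at this place, para to a large group, is enough to carry the number well beyond the scatter. The earlier compounds shown here gave no such reading, as no two of them differed in one place only. Nothing available here accounts for this loss. As far as these compounds go, whether a methoxy group, a hydroxyl group or an amine at this place would behave like methyl stays open. So does whether methyl would have the same effect on the core of compound 3.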